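Chain Lengthening of Hydroxamates in Two Related Cores

The compounds below may be only part of what the source reports. "The series", "measured", "known", "first", "only" and "open" are said of these compounds alone.

Compound 1, `Nc1nc2cc(-c3nn(CCCCC(=O)NO)c4ncnc(N)c34)ccc2o1`, gives 14000 nM in a functional assay on MCF7 cells (Homo sapiens) for inhibition, read by MTT assay, with a stated time of 72 h; a lower number here means a stronger inhibitor, a higher number a weaker inhibitor. Compound 3, `Nc1nc2cc(-c3nn(CCCCCC(=O)NO)c4ncnc(N)c34)ccc2o1`, gives 12400 nM in this assay. Compound 2, `Nc1ncnc2c1c(-c1cnc3[nH]ccc3c1)nn2CCC(=O)NO`, reaches only the limit > 150000 nM in this assay, which is not a number.

The change from compound 1 to compound 3 is (hydroxycarbamoyl)methyl in place of hydroxycarbamoyl on a saturated chain carbon, four bonds along the chain from an aromatic nitrogen, and the step is a 1.1-fold lower number from compound 1 to compound 3 (0.05 log units; within the scatter). Compound 4, `Nc1ncnc2c1c(-c1cnc3[nH]ccc3c1)nn2CCCC(=O)NO`, is not yet measured; it differs from compound 2 by (hydroxycarbamoyl)methyl in place of hydroxycarbamoyl on a saturated chain carbon, two bonds along the chain from an aromatic nitrogen. This is the same kind of change, but the place differs: two bonds along the chain from an aromatic nitrogen rather than four. The difference between the two cores is not broken down here.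

Because compound 2 sits at the limit of > 150000 nM in this assay, at which 1 of the 3 values shown sits, and the measured step of this kind was within the scatter, the estimated step of a number no higher from compound 2 to compound 4 (the limit leaves the size open) for compound 4 is expected to be small. Compound 4 is estimated at 150000 nM, expected between 60000 nM and 300000 nM, most likely again a limit.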

Compound 4, half-maximal inhibitory concentration: > 150000 nM
Compound 4 was reported as a limit (the forecaster's own chance of this, stated with the estimate: 65%); the middle value sits exactly at the limit.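

Among the compounds shown here, compound 2 and compound 4 are both reported only as limits in this assay, and no step between them can be read. The compounds shown leave open whether this chain lengthening changes the number on the core of compound 2 at all.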